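The source may hold more compounds than are shown below. What is called first, only, known or untested is meant among the compounds shown, and "the series" means these compounds.

Among the compounds with values here, compound 2, `COc1ccc(CN(C(=O)CSc2nc3ccccc3s2)c2cc(OC)c(OC)c(OC)c2)cc1C`, gives 17100 nM in a functional assay on HCT-116 cells (Homo sapiens) for antiproliferative activity, read by MTT assay, with a stated time of 48 h (on this read-out higher numbers stand for weaker inhibition and lower numbers for stronger inhibition), the highest of the three numbers known: compound 3, `COc1ccc(CN(C(=O)CSc2nc3cc(Br)ccc3s2)c2cc(OC)c(OC)c(OC)c2)cc1O`, gives 3380 nM, and compound 1, `COc1ccc2nc(SCC(=O)N(Cc3ccc(OC)c(O)c3)c3cc(OC)c(OC)c(OC)c3)sc2c1`, gives 352 nM. Within the data shown here, the only single-point step known, a 9.6-fold higher number from compound 1 to compound 3 (0.98 log units; beyond the scatter), concerns the other end of the molecule and does not bear on the change studied here. Compound 4, `COc1ccc(CN(C(=O)CSc2nc3ccccc3s2)c2cc(OC)c(OC)c(OC)c2)cc1N`, differs from compound 2 by amino in place of methyl on an aromatic carbon. Among the measured compounds shown here, no measured step addresses this exchange, but compound 1 and compound 3, which carry a hydroxyl at the corresponding place, both show lower numbers than compound 2. Compound 4 is therefore expected to give a lower number, a step of about a 4.9-fold lower number from compound 2 to compound 4 (0.69 log units; beyond the scatter), with an estimate of 3500 nM and a range from 900 nM to 14000 nM.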

Compound 4, half-maximal inhibitory concentration: 491 nM
The estimate for compound 4 lay 7.1-fold (0.85 log units) above the measured number; measured number below the stated range.
By their numbers in this assay, from the lowest: compounds 1 and 4 (each within the scatter of the next); then compound 3; then compound 2.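

In this assay the exchange at this place, ortho to a methoxy group, is a large one: a 35-fold lower number from compound 2 to compound 4 (1.54 log units; beyond the scatter). Amino in place of methyl on this aromatic carbon thus changes the read-out strongly, which the earlier compounds could not show, as their only single-point step lay at the other end of the molecule. No measurement at hand accounts for the size of this step. Open, going by these compounds, is how a dimethylamino group or an acetamido group would read at this place on the core of compound 2. Also open, on these data alone, is whether amino in place of methyl gives a similar step on the core of compound 3.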